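The source may report more compounds than this note shows. Statements on the series, on what has been measured and on what is new or still open speak of the compounds shown alone.

Compound 2 `O=C(Nc1ccccc1C(F)(F)F)C1CCc2ccccc2N1C(=O)c1ccccc1Cl` stands lowest of the three compounds measured in a functional assay on ACHN cells (Homo sapiens) for cytotoxicity, read by sulforhodamine B assay, with a stated time of 72 h (on this read-out higher numbers stand for weaker inhibition of growth and lower numbers for stronger inhibition of growth), where compound 2 gives 3900 nM. Among the compounds with values here, its nearest neighbour is compound 3 `O=C(Nc1ccccc1O)C1CCc2ccccc2N1C(=O)c1ccccc1Cl`, which in this assay gives 44200 nM; the one change between them, hydroxy in place of trifluoromethyl on an aromatic carbon, brings an 11-fold higher number from compound 2 to compound 3 (1.05 log units; beyond the scatter). Furthest away lies compound 1 `O=C(Nc1ccccc1)C1CCc2ccccc2N1`, which in this assay gives 72900 nM; compound 1 differs from compound 2 in two places at once, so the two values show only that the core with no acyl group on the ring nitrogen and an unsubstituted anilide sits far weaker.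

Compound 4 `CC(=O)N1c2ccccc2CCC1C(=O)Nc1ccccc1C(F)(F)F` keeps the trifluoromethyl anilide of compound 2 and alters the acyl group on the ring nitrogen: methyl in place of 2-chlorophenyl on a carbonyl carbon. Within the data shown here, no measured step touches this carbonyl carbon, so nothing bears directly on the size of the change. Among the measured compounds shown here, the only guidance is that compound 1, with no acyl group at all, lies far higher, though that comparison is confounded by its other difference. A weaker inhibition of growth is therefore expected, of moderate to large size. Compound 4 is expected to give 15000 nM, between 5000 nM and 50000 nM. The expected step is a 3.8-fold higher number from compound 2 to compound 4 (0.59 log units; beyond the scatter).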

Compound 4, concentration for 50% growth inhibition: > 80000 nM
Compound 4 ended at the assay's limit; the forecaster's own chance of this, stated with the estimate: 5%; at least 5.3-fold (0.72 log units) between middle value and limit.
By their numbers in this assay, from the lowest: compound 2; then compounds 3 and 1 (each within the scatter of the next). At a limit, above all of these: compound 4.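

Methyl in place of 2-chlorophenyl on a carbonyl carbon, with the trifluoromethyl anilide kept, brings an at least 20-fold higher number from compound 2 to compound 4 (1.31 log units; beyond the scatter), the first measured step that changes the acyl group alone. In this assay, from the compounds shown here alone, compound 4 gives > 80000 nM, which is a limit of the assay and not a number, so the full size of the step stays unknown: the limit of > 80000 nM in this assay, at which 1 of the 4 values shown sits. Compound 1 had differed from compound 2 in two places at once, whereas this pair differs in one place and shows that, with this anilide, growth inhibition at the level of compound 2 depends strongly on which group stands on this carbonyl carbon.

With only 2-chlorophenyl and methyl shown on this carbon, the compounds leave open whether the difference follows the aromatic ring or its chlorine, which an unsubstituted phenyl would help to separate. They also leave open how a longer chain such as butyl, or a saturated ring such as cyclohexyl, would fare in this place, and whether the step would keep its size with another anilide.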